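A few compounds are considered here, and "the series" means these few. Any claim that something is new, unique, unknown or untested is made for them only; others in the source may bear on it.

Measured compounds:
- compound 1, `Cc1c(OCCCCOc2ccc(C(=O)O)c(F)c2)ccc(C(=O)CC(C)(C)C)c1O`: 80 nM in an assay for positive allosteric modulation of metabotropic glutamate receptor 2 (Rattus norvegicus); on this read-out lower numbers stand for an effect already at smaller amounts and higher numbers for an effect only at larger amounts of compound
- compound 2, `Cc1c(OC[C@@H](C)COc2ccc(F)c(C(=O)O)c2)ccc(C(=O)CC(C)(C)C)c1O`: 112 nM

Of the two numbers gathered so far in this assay, compound 2 gives the higher one. Its nearest neighbour is compound 1, which gives a lower number, but that gap falls within the scatter, so the two compounds cannot be told apart on this read-out. Compound 2 and compound 1 also differ in more than one place, so no single change can be read from them.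

The unmeasured compound 3, `Cc1c(OC[C@@H](C)COc2ccc(C(=O)O)c(Cl)c2)ccc(C(=O)CC(C)(C)C)c1O`, arises from compound 2 by one change: 4-carboxy-3-chlorophenyl in place of 3-carboxy-4-fluorophenyl on an oxygen on a saturated carbon. The shared core and the rest of the molecule stay untouched. For the measured compounds named here, no step between measured compounds isolates this exchange, so there is nothing to lean on beyond the fact that both measured compounds, carrying a carboxylic acid and a halogen on the aromatic ring in two different arrangements, land near each other in this assay.

The expectation is therefore a step from compound 2 to compound 3 of a 1.1-fold lower number from compound 2 to compound 3 (0.05 log units; within the scatter), that is, nothing beyond the scatter. Compound 3 is estimated at 100 nM, with a range from 35 nM to 300 nM.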

Compound 3, half-maximal effective concentration: 50 nM
Compound 3: the middle estimate sits 2.0-fold (0.30 log units) above what was measured; the measured number falls inside the stated range.
By their numbers in this assay, from the lowest: compounds 3, 1 and 2 (each within the scatter of the next, the first and the last beyond it).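

In this assay, putting 4-carboxy-3-chlorophenyl in place of 3-carboxy-4-fluorophenyl on an oxygen on a saturated carbon gives a 2.2-fold lower number from compound 2 to compound 3 (0.35 log units; beyond the scatter), the first single-place comparison available in this series, with the rest of the molecule unchanged. It shows that this place is not indifferent to how the aromatic ring is decorated, even though both groups have the same heavy-atom count and both carry a carboxylic acid and a halogen. Fluorine gives way to chlorine and the arrangement of the groups on the ring changes in the same exchange, so the step belongs to the exchange as a whole, and nothing available explains why it occurs.

As far as these compounds go, what remains open is how much of the step comes from the halogen and how much from the arrangement; 3-carboxy-4-chlorophenyl at this same place would begin to separate the two. It is also unknown whether the trend would continue with bromine in place of chlorine, or whether a halogen is needed at all.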